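The source may report more compounds than this note shows. Statements on the series, on what has been measured and on what is new or still open speak of the compounds shown alone.

Measured compounds:
Compound 1 `c1csc(-c2csnn2)c1` gives 66900 nM in an ADME assay on MCF7 cells (Homo sapiens) for cytotoxicity, read by MTT assay, with a stated time of 48 h; a higher number here means a weaker inhibitor, a lower number a stronger inhibitor.
Compound 2 `C/C(=N\NC(=O)COc1cccc2cccnc12)c1ccccn1` gives only a limit, > 100000 nM, in this assay.

Compound 2 therefore stands at the limit of > 100000 nM in this assay, at which 1 of the 2 values shown sits, and no number is known for it. Compound 3 `C/C(=N\NC(=O)COc1cccc2cccnc12)c1ccco1` differs from compound 2 by furan-2-yl in place of pyridin-2-yl on a carbon with a double bond to nitrogen. No measured step of this kind exists among the compounds shown. The step from compound 2 to compound 3 is expected to be a step that the limit leaves unreadable from compound 2 to compound 3, within the scatter, in no clear direction. Compound 3 is estimated at 120000 nM in this assay, with a range from 40000 nM to 400000 nM.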

Compound 3, half-maximal inhibitory concentration: > 100000 nM
Compound 3: no number, only a limit; the forecaster's own chance of this, stated with the estimate: 70%; the middle value is on the limit's open side.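

Compound 2 and compound 3 each give only a limit in this assay, so no step can be read from one to the other: the limit of > 100000 nM in this assay, at which 2 of the 3 values shown sit.

As far as these compounds go, whether furan-2-yl in place of pyridin-2-yl changes the value at all remains open.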